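The source may hold more compounds than are shown below. What is called first, only, known or untested is meant among the compounds shown, and "the series" means these compounds.

Measured compounds:
compound 1, `COc1cccc2c1c(C(=O)/C=C(\O)C(=O)O)cn2Cc1cccc(F)c1F`: 17500 nM
compound 2, `COc1cccc2c1c(C(=O)/C=C(\O)C(=O)O)cn2Cc1ccc(F)cc1F`: 20800 nM
compound 3, `CCOC(=O)/C(O)=C/C(=O)c1cn(Cc2cccc(F)c2F)c2cccc(OC)c12`: 21100 nM

The three compounds share a core and were all read in an ADME assay on MT4 cells (Homo sapiens) for cytotoxicity, read by MTT assay; on this read-out higher numbers stand for lower toxicity in this test and lower numbers for higher toxicity in this test. Compound 1 gives 17500 nM in this assay, compound 2 gives 20800 nM and compound 3 gives 21100 nM. The change from compound 1 to compound 2 is 2,4-difluorophenyl in place of 2,3-difluorophenyl on a saturated chain carbon bound to an aromatic nitrogen, and it makes a step of a 1.2-fold higher number from compound 1 to compound 2 (0.08 log units; within the scatter). The change from compound 1 to compound 3 is ethyl in place of hydrogen on an oxygen next to a carbonyl group, with a step of a 1.2-fold higher number from compound 1 to compound 3 (0.08 log units; within the scatter). Neither step stands out from the scatter of repeated measurements, so the three values lie together.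

Compound 4, `CCOC(=O)/C(O)=C/C(=O)c1cn(Cc2ccc(F)cc2F)c2cccc(OC)c12`, has not yet been measured. Within the data shown here, it differs from compound 3 by 2,4-difluorophenyl in place of 2,3-difluorophenyl on a saturated chain carbon bound to an aromatic nitrogen, which is the same change, at the same place, as the one that leads from compound 1 to compound 2. Because that earlier change gave a 1.2-fold higher number from compound 1 to compound 2 (0.08 log units; within the scatter), and because compound 3 itself sits at 21100 nM, the step from compound 3 to compound 4 is expected to be small, about a 1.1-fold higher number from compound 3 to compound 4 (0.06 log units; within the scatter). The expectation rests on a single prior instance of this change, so its spread is taken generously. Compound 4 is accordingly estimated at 24000 nM in this assay, with a likely range from 13000 nM to 44000 nM.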

Compound 4, half-maximal cytotoxic concentration: 65500 nM
Compound 4: middle estimate off by 2.7-fold (0.44 log units), on the low side, outside the stated range (above it).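

In this assay, 2,4-difluorophenyl in place of 2,3-difluorophenyl on a saturated chain carbon bound to an aromatic nitrogen gives a 3.1-fold higher number from compound 3 to compound 4 (0.49 log units; beyond the scatter), yet this step cannot be told apart from the earlier instance of the same change, as the gap between the two stays within what two such steps can scatter: the same change on two cores in this assay, a 1.2-fold higher number (0.08 log units; within the scatter) from compound 1 to compound 2 and a 3.1-fold higher number (0.49 log units; beyond the scatter) from compound 3 to compound 4, 2.6-fold (0.42 log units) apart, within the scatter of two such steps

Ethyl in place of hydrogen on an oxygen next to a carbonyl group gives a 3.1-fold higher number from compound 2 to compound 4 (0.50 log units; beyond the scatter), and the comparison with its earlier instance comes out the same way: the same change on two cores in this assay, a 1.2-fold higher number (0.08 log units; within the scatter) from compound 1 to compound 3 and a 3.1-fold higher number (0.50 log units; beyond the scatter) from compound 2 to compound 4, 2.6-fold (0.42 log units) apart, within the scatter of two such steps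

Among these compounds, the series therefore gives no firm sign that either change acts differently from one core to another, but it does not show that either carries over unchanged, since each comparison rests on a single pair of steps and both of the larger steps end on the one value of compound 4.

Going by these compounds, whether the larger steps would recur with an unsubstituted benzyl group or a chlorine on the phenyl ring remains open. On these data alone, it is also open how a methyl ester or a primary amide in place of the ethyl ester would read in this assay.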